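Notes on a fluoropyridine swap in the series

The compounds below may be only part of what the source reports. "The series", "measured", "known", "first", "only" and "open" are said of these compounds alone.

Measured so far in an ADME assay on the whole organism (plasma, Rattus norvegicus) for protein binding, using cassette dosing, at a dose of 1 mg/kg; a higher number here means a larger unbound share of the compound, a lower number a smaller unbound share:
- compound 1 `CC(C)Oc1ccc(/N=c2\[nH]c(=O)n(C[C@@H](O)CO)c(=O)n2Cc2ccc(Cl)cc2)cc1Cl` gives 0.001 
- compound 2 `C[C@@H](Cn1c(=O)[nH]/c(=N\c2ccc(Oc3ccc(F)cn3)cc2)n(Cc2ccc(Cl)cc2)c1=O)C(=O)O` gives 0.011 

Compound 2 stands highest of the two, with a gap to compound 1 beyond the scatter. Unmeasured compound 3 `C[C@@H](Cn1c(=O)[nH]/c(=N\c2ccc(Oc3ccnc(F)c3)cc2)n(Cc2ccc(Cl)cc2)c1=O)C(=O)O` carries 2-fluoropyridin-4-yl in place of 5-fluoropyridin-2-yl on an oxygen on an aromatic ring and keeps the same atoms, joined differently. Going by the values given here, no measured step covers this change, so the expectation starts from compound 2 at 0.011 and assumes no clear direction. The expected 1.1-fold higher number from compound 2 to compound 3 (0.04 log units; within the scatter) stays within the scatter. For compound 3 the estimated value is 0.012, with an expected range of 0.005 to 0.03.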

Compound 3, unbound fraction: 0.013
Beside the measured number, compound 3's estimate is 1.1-fold (0.03 log units) below it; the measured number falls inside the stated range.
By their numbers in this assay, from the lowest: compound 1; then compounds 2 and 3 (each within the scatter of the next).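

In this assay, going by these compounds alone, the swap of 5-fluoropyridin-2-yl for 2-fluoropyridin-4-yl on an oxygen on an aromatic ring gives a 1.2-fold higher number from compound 2 to compound 3 (0.07 log units; within the scatter) and provides the first one-place comparison. For this pair, rearranging the same atoms leaves the unbound fraction within the scatter. No available evidence accounts for this result.

Open, as far as these compounds go, is whether this position stays as flat with an unsubstituted phenyl or with a pyridine carrying an amine. Also open, from the compounds shown here alone, is how the unbound fraction responds when an amide replaces the carboxylic acid.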